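A few compounds are considered here, and "the series" means these few. Any claim that something is new, unique, unknown or untested is made for them only; others in the source may bear on it.

Working notes on a small set of diaminotriazine spiro compounds tested in an assay on isolated protein for inhibition of Dihydrofolate reductase (Homo sapiens), read by spectrophotometry, using NADPH, with stated times of 5 s and 6 min, tested at 5 uM; a lower number here means a weaker effect, a higher number a stronger effect of the compound at the concentration tested.

Compound 1, `NC1=NC2(CCSCC2)N(OCCCOc2ccccc2Br)C(N)=N1`, gives 88.7% in this assay. Compound 3, `NC1=NC2(CCSCC2)N(OCCCOc2ccccc2Cl)C(N)=N1`, gives 86.3%. The two differ in one place only, (chloro in place of bromo on an aromatic carbon), and the step this makes, a number 2.4 percentage points lower from compound 1 to compound 3 (within the scatter), does not exceed the scatter of the assay. Compound 2, `NC1=NC2(CCOCC2)N(OCCCOc2cccc(Br)c2)C(N)=N1`, gives 86.7%, a number that lies within the scatter of both compound 1 and compound 3. Compound 2 carries a different core from compound 1, and the difference between the two cores is not broken down here.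

Compound 4, `NC1=NC2(CCOCC2)N(OCCCOc2cccc(Cl)c2)C(N)=N1`, has not been measured in this assay. It stands to compound 2 as compound 3 stands to compound 1: chloro in place of bromo on an aromatic carbon. The place differs between the two pairs: in compound 1 the exchanged group sits ortho to a large group, in compound 2 it sits meta to a large group, so this is the same kind of change rather than the same change. Within the data shown here, the only measured step of this kind, from compound 1 to compound 3, stayed within the scatter, and on that basis the step from compound 2 to compound 4 is expected to be about a number 2.2 percentage points lower from compound 2 to compound 4 (within the scatter), again within the scatter. Among the measured compounds shown here, compound 4 is thus estimated at 84.5%, with the expected range running from 78% to 90% because the only comparable step, a number 2.4 percentage points lower from compound 1 to compound 3 (within the scatter), was small.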

Compound 4, a percentage reported as inhibition, at one concentration (the size of the read-out at that concentration, not a potency): 83.2%
Estimate against measurement, compound 4: 1.3 percentage points above; measured number inside the range.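

In this assay, chloro in place of bromo on an aromatic carbon gives a number 3.5 percentage points lower from compound 2 to compound 4 (within the scatter), and set beside the earlier step, the change carries over from one core to the other without a detectable difference: the same change on two cores in this assay, a number 2.4 percentage points lower (within the scatter) from compound 1 to compound 3 and a number 3.5 percentage points lower (within the scatter) from compound 2 to compound 4, 1.1 percentage points apart, within the scatter of two such steps

Among these compounds, this shows only that the exchange stayed small on both cores; since neither step leaves the scatter, it does not show that chloro and bromo differ, and the agreement is one of two small steps rather than a measured effect repeated. The two pairs also differ in where the exchanged group sits as well as in the core, so the contributions of core and place cannot be separated, and two pairs read at a single concentration, which gives no potency, make no general rule for other cores.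

The compounds shown leave open whether a fluoro, a methyl, a trifluoromethyl or a methoxy on the same aromatic ring would stay as close to bromo and chloro as these two stay to each other. They also leave open how an amine or a carboxylic acid on that ring, or a longer chain to the phenoxy group, would read in this assay.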